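Adding a Cyano Group to Compound 3

The compounds below may be only part of what the source reports. "The series", "measured", "known", "first", "only" and "open" are said of these compounds alone.

Within the data shown here, in a functional assay on U-373MG ATCC cells (Homo sapiens) for inhibition, read by MTT assay, with a stated time of 72 h (on this read-out lower numbers stand for stronger inhibition and higher numbers for weaker inhibition), compound 3 `CC1(C)CC(NC(=S)Nc2ccccc2)c2cc(Cl)ccc2O1` gives 46000 nM, the highest and therefore the weakest of the three numbers measured so far. Compound 2 `CC1(C)CC(NC(=S)Nc2ccc(C#N)cc2)c2cc(Cl)ccc2O1` gives 10000 nM, and compound 1 `CC1(C)CC(NC(=S)Nc2cccc(C#N)c2)c2cc(Br)ccc2O1` gives 6000 nM; these two values lie within the usual scatter of each other.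

The unmeasured compound 4 `CC1(C)CC(NC(=S)Nc2cccc(C#N)c2)c2cc(Cl)ccc2O1` differs from compound 3 in one place: cyano in place of hydrogen on an aromatic carbon. This is cyano in place of hydrogen on an aromatic carbon, meta to a large group, so phenyl becomes 3-cyanophenyl.

Among the measured compounds shown here, one measured step bears directly on this change: a 4.6-fold higher number from compound 2 to compound 3 (0.66 log units; beyond the scatter). It is modest but beyond the scatter, and it removes a cyano group sitting at a different place on the ring. Read in reverse, it suggests that adding cyano lowers the number. Compound 1 also carries 3-cyanophenyl, with a different halogen on the core, and its 6000 nM points the same way.

A downward step of similar size is therefore expected, a 5.1-fold lower number from compound 3 to compound 4 (0.71 log units; beyond the scatter). For compound 4 the estimated value is 9000 nM, with an expected range from 4000 nM to 20000 nM.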

Compound 4, half-maximal inhibitory concentration: 7000 nM
For compound 4 the middle estimate is 1.3-fold (0.11 log units) above the measured one; low and high end bracket the measured number.
By their numbers in this assay, from the lowest: compounds 1, 4 and 2 (each within the scatter of the next); then compound 3.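

In this assay, the cyano group now has a direct test at this place on the ring, with chloro kept on the core (a 6.6-fold lower number from compound 3 to compound 4 (0.82 log units; beyond the scatter)), so the lower number seen with 4-cyanophenyl also appears with 3-cyanophenyl. The two cyano placements cannot be told apart here (a 1.4-fold lower number from compound 2 to compound 4 (0.15 log units; within the scatter)), and neither can the two halogens when 3-cyanophenyl is present (a 1.2-fold higher number from compound 1 to compound 4 (0.07 log units; within the scatter)), since both steps lie within the scatter. No measurement shown explains what the cyano group does in these cells.

As far as these compounds go, whether another group at this place, such as an amine, a carboxylic acid or a methoxy group, would also lower the number remains open. It is also unknown whether a methyl group in place of the halogen on the core would leave the number unchanged.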